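This account rests on a few compounds, and the source may have more. Where it says the series, first, only, none or still open, it means among the compounds named here.

Measured compounds:
Compound 1, `CC(=O)c1ccc(NC(=O)CSc2nc3c([nH]2)c(=O)n(C)c(=O)n3C)cc1`: 6900 nM
Compound 2, `CC(=O)c1ccc(NC(=O)CSc2nc3[nH]c(=O)n(C)c(=O)c3[nH]2)cc1`: 7700 nM
Compound 3, `Cn1c(=O)c2[nH]c(SCC(=O)c3ccccc3)nc2n(C)c1=O`: 6700 nM

All three were tested in a functional assay on A549 cells (Homo sapiens) for inhibition, read by MTT assay, with a stated time of 48 h; a lower number here means a stronger inhibitor, a higher number a weaker inhibitor. Compound 1 and compound 2 differ in one place, (hydrogen in place of methyl on an aromatic nitrogen), and this gave a 1.1-fold higher number from compound 1 to compound 2 (0.05 log units; within the scatter). Compound 3 carries a different side chain on its core; the difference between the cores of compound 1 and compound 3 is not broken down here, and the values of compound 1 and compound 3 lie within the usual scatter of each other.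

Compound 4, `Cn1c(=O)[nH]c2nc(SCC(=O)c3ccccc3)[nH]c2c1=O`, has not yet been measured. It differs from compound 3 by hydrogen in place of methyl on an aromatic nitrogen, the same change that turns compound 1 into compound 2. The step is expected to be a 1.1-fold higher number from compound 3 to compound 4 (0.04 log units; within the scatter), because the same change earlier gave a 1.1-fold higher number from compound 1 to compound 2 (0.05 log units; within the scatter). Compound 4 is therefore estimated to give 7400 nM in this assay, somewhere from 3500 nM to 15000 nM.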

Compound 4, half-maximal inhibitory concentration: 11900 nM
The estimate for compound 4 lay 1.6-fold (0.21 log units) below the measured number; measured number inside the range.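

Putting hydrogen in place of methyl on the aromatic nitrogen gave a 1.8-fold higher number from compound 3 to compound 4 (0.25 log units; within the scatter) in this assay. Set beside the earlier step, this one does not differ from it by more than the scatter: the same change on two cores in this assay, a 1.1-fold higher number (0.05 log units; within the scatter) from compound 1 to compound 2 and a 1.8-fold higher number (0.25 log units; within the scatter) from compound 3 to compound 4, 1.6-fold (0.20 log units) apart, within the scatter of two such steps. The change therefore carries across these two cores without a detectable difference, but each step lies within the scatter, so the two pairs show no real effect of the change on either core and say nothing about any other core.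

The compounds shown leave open whether a longer chain in place of methyl on that nitrogen would shift the number beyond the scatter. They also leave open how an amine or a carboxylic acid in the side chain would read.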